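From hydroxy to methoxy on compound 2

The source may report more compounds than this note shows. Statements on the series, on what has been measured and on what is new or still open speak of the compounds shown alone.

Of the compounds shown here, two have numbers so far. In a functional assay on HT-29 cells (Homo sapiens) for inhibition, read by MTT assay, with a stated time of 2 days (a higher number here means a weaker inhibitor, a lower number a stronger inhibitor), compound 1 (`Oc1ccccc1/C=C/c1ccccc1O`) gives 25 ug/mL and compound 2 (`Oc1cccc(/C=C/c2cccc(O)c2)c1`) gives 25.9 ug/mL and so sits within the usual scatter of compound 1. Compound 3 (`COc1cccc(/C=C/c2cccc(O)c2)c1`) is compound 2 with a hydroxy turned into a methoxy (methyl in place of hydrogen on an oxygen on an aromatic ring): methyl in place of hydrogen on an oxygen on an aromatic ring. For the measured compounds named here, no measured pair shows this change, so nothing yet gives its size directly. Going by the values given here, the only starting point is compound 2 at 25.9 ug/mL and little movement is expected in this assay, perhaps a slightly lower number. The estimate is a 1.2-fold lower number from compound 2 to compound 3 (0.07 log units; within the scatter) as the expected step, which would stay within the scatter. Compound 3 is expected at 22 ug/mL (estimated range 9 ug/mL to 55 ug/mL).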

Compound 3, half-maximal inhibitory concentration: 11.5 ug/mL
Estimate against measurement, compound 3: 1.9-fold (0.28 log units) above; low and high end bracket the measured number.
By their numbers in this assay, from the lowest: compound 3; then compounds 1 and 2 (each within the scatter of the next).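

Turning one hydroxy of compound 2 into a methoxy gives, in this assay, a 2.3-fold lower number from compound 2 to compound 3 (0.35 log units; beyond the scatter) and so moves the result towards a stronger inhibitor. For the compounds shown here, until now, every measured compound carried only hydroxy groups on its aromatic rings, so this is the first pair to show that a methyl on an oxygen on an aromatic ring can change the number by more than the usual scatter. Nothing measured here bears on why the number falls.

The compounds shown leave open whether turning the remaining hydroxy of compound 3 into a methoxy as well would lower the number further. They also leave open whether the methyl itself matters, which an ethoxy, a longer chain on the same oxygen, or an amine in place of the hydroxy could help to test.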